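A few compounds are considered here, and "the series" means these few. Any claim that something is new, unique, unknown or untested is made for them only; others in the source may bear on it.

In an assay on isolated protein for inhibition of RAC-alpha serine/threonine-protein kinase (Homo sapiens), read by ELISA, tested at 100 uM (on this read-out lower numbers stand for less inhibition and higher numbers for more inhibition at the one concentration tested (going by the name of the read-out)), compound 1, `O=S(=O)(O)C[C@H]1O[C@@H](OC(CO)CO)[C@H](O)[C@@H](O)[C@@H]1O`, gives 13%, while compound 2, `CCCCCCCCCCCCCCCCCC(=O)OCC(CO)O[C@@H]1O[C@H](CS(=O)(=O)O)[C@@H](O)[C@H](O)[C@H]1O`, gives 86%. Compound 2 therefore stands highest of the two numbers, and its nearest neighbour, compound 1, lies beyond the scatter below it. Compound 3, `CCCCCC(=O)OCC(CO)O[C@@H]1O[C@H](CS(=O)(=O)O)[C@@H](O)[C@H](O)[C@H]1O`, has not been measured; it differs from compound 2 in one place: hydrogen in place of dodecyl on a saturated chain carbon, five bonds along the chain from a carbonyl carbon. With the chain shortened, the value is expected to fall, the step of a number 56 percentage points lower from compound 2 to compound 3 (beyond the scatter) being expected to go well beyond the scatter. Compound 3 is expected to give about 30%, within a range from 10% to 60%.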

Compound 3, a percentage reported as inhibition, at one concentration (the size of the read-out at that concentration, not a potency): 18%
Compound 3: middle estimate off by 12 percentage points, on the high side; low and high end bracket the measured number.
By their numbers in this assay, from the lowest: compounds 1 and 3 (each within the scatter of the next); then compound 2.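

In this assay the dodecyl portion of the chain carries almost the whole effect at this position, with a number 68 percentage points lower from compound 2 to compound 3 (beyond the scatter) once hydrogen replaces it. The pentylcarbonyl group left behind adds nothing that can be told apart from hydrogen on that oxygen, with a number 5 percentage points higher from compound 1 to compound 3 (within the scatter) in the same assay. Nothing measured here explains why the chain matters so much. The compounds shown leave open how the number changes between these two chain lengths, as with an octanoyl or decanoyl ester, and whether a longer chain would go higher still. They also leave open whether an amide in place of the ester would keep the inhibition seen with compound 2.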